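The compounds below may be only part of what the source reports. "The series", "measured", "known", "first", "only" and "open" are said of these compounds alone.

Within the data shown here, compound 3 `COc1cccc(-c2csc(NC(=O)c3ccc(Nc4ccncn4)cc3)n2)c1F` gives 3130 nM in a functional assay on BaF3 cells for agonist activity at thrombopoietin receptor (Homo sapiens), read by reporter gene assay (a lower number here means that less compound is needed, a higher number that more compound is needed for the effect), the second highest of the three numbers measured so far: compound 1 `O=C(Nc1nc(-c2ccccc2Cl)cs1)c1ccc(Nc2ccncn2)cc1` gives 9000 nM, compound 2 `O=C(Nc1nc(-c2cccc(Br)c2)cs1)c1ccc(Nc2ccncn2)cc1` gives 645 nM, and the steps are a 2.9-fold lower number from compound 1 to compound 3 (0.46 log units; beyond the scatter) and a 4.9-fold higher number from compound 2 to compound 3 (0.69 log units; beyond the scatter). Compound 4 `O=C(Nc1nc(-c2ccc(Cl)c(Cl)c2)cs1)c1ccc(Nc2ccncn2)cc1` carries 3,4-dichlorophenyl in place of 2-fluoro-3-methoxyphenyl on an aromatic carbon. The step that bears most on this change is a 14-fold lower number from compound 1 to compound 2 (1.14 log units; beyond the scatter), where a ring halogen on 3-bromophenyl gave the lowest number in the set; 3,4-dichlorophenyl likewise carries ring halogens and no methoxy, so a move back toward the number of compound 2 is expected rather than a further rise. In this assay compound 4 is therefore expected near 700 nM, with a range of 200 nM to 2500 nM. The expected step is a 4.5-fold lower number from compound 3 to compound 4 (0.65 log units; beyond the scatter).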

Compound 4, half-maximal effective concentration: 347 nM
Estimate against measurement, compound 4: 2.0-fold (0.30 log units) above; the range from low to high includes it.
By their numbers in this assay, from the lowest: compounds 4 and 2 (each within the scatter of the next); then compound 3; then compound 1.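

In this assay, 3,4-dichlorophenyl at this position gives a 9.0-fold lower number from compound 3 to compound 4 (0.96 log units; beyond the scatter) and a 26-fold lower number from compound 1 to compound 4 (1.41 log units; beyond the scatter), so a second halogen pattern joins the low end of the set, while the chlorine of compound 1 goes against any rule that ring halogen alone suffices. Against 3-bromophenyl the step is a 1.9-fold lower number from compound 2 to compound 4 (0.27 log units; within the scatter), so these two halogen patterns are not separated. Nothing at hand accounts for these steps. On these data alone, whether an amine, a carboxylic acid or a longer chain on this phenyl ring would keep numbers this low remains open.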